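A few compounds are considered here, and "the series" means these few. Any claim that something is new, unique, unknown or untested is made for them only; others in the source may bear on it.

Working notes on the series. The shared core of compound 2 `C=C[C@@](C)(CC[C@H]1C(C)=CC[C@H]2C(C)(C)CCC[C@]12C)O[C@@H]1O[C@H](C)[C@H](O)[C@H](O)[C@H]1O` is carried through all members; in a functional assay on SK-OV-3 cells (Homo sapiens) for cytotoxicity, read by sulforhodamine B assay (on this read-out higher numbers stand for an effect only at larger amounts of compound and lower numbers for an effect already at smaller amounts), compound 2 gives 3.6 ug/mL. Compound 1 `C=C[C@@](C)(CC[C@H]1C(C)=CC[C@H]2C(C)(C)CCC[C@]12C)O[C@@H]1O[C@@H](C)[C@@H](OC(C)=O)[C@H](O)[C@H]1O` gives 3.4 ug/mL in this assay, and compound 3 `C=C[C@@](C)(CC[C@H]1C(C)=CC[C@H]2C(C)(C)CCC[C@]12C)O[C@@H]1O[C@H](C)[C@H](OC(C)=O)[C@H](O)[C@H]1O` gives 5.8 ug/mL. Compound 2 thus stands second highest of the three numbers, with compound 1 nearest and compound 3 furthest, all three within the scatter of one another.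

Compound 4 `C=C[C@@](C)(CC[C@H]1C(C)=CC[C@H]2C(C)(C)CCC[C@]12C)O[C@@H]1O[C@@H](C)[C@@H](O)[C@H](O)[C@H]1O` is not yet measured. Its difference from compound 2 is the two compounds have the same atoms and bonds and differ only in configuration as drawn: 2 of 9 stereo elements differ; a stereocentre at a saturated ring carbon is drawn R in compound 2 and S in compound 4; a stereocentre at a saturated ring carbon is drawn R in compound 2 and S in compound 4. The same kind of change already has a measured counterpart: compound 1 and compound 3 differ only in configuration as drawn (the fact that compounds 1 and 3 differ only in the configuration as drawn), and that pair gave a 1.7-fold higher number from compound 1 to compound 3 (0.23 log units; within the scatter). Within the data shown here, the acetyl step a 1.6-fold higher number from compound 2 to compound 3 (0.21 log units; within the scatter) also stayed within the scatter, so nothing in the three numbers so far separates the members. On that basis no step beyond the scatter is expected for compound 4; the estimated move from compound 2 is no change at the digits printed from compound 2 to compound 4 (within the scatter). Compound 4 is therefore expected at 3.6 ug/mL in this assay, with a range from 2 ug/mL to 6.5 ug/mL.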

Compound 4, concentration for half-maximal effect: 5.7 ug/mL
For compound 4 the middle estimate is 1.6-fold (0.20 log units) below the measured one, within the range that was stated.
By their numbers in this assay, from the lowest: compounds 1, 2, 4 and 3 (each within the scatter of the next).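

In this assay the change in configuration at the two saturated ring carbons, now read on the compounds without acetyl, gives a 1.6-fold higher number from compound 2 to compound 4 (0.20 log units; within the scatter), and hydrogen in place of acetyl on the oxygen on a saturated carbon gives a 1.7-fold higher number from compound 1 to compound 4 (0.22 log units; within the scatter). Each step alone stays within the scatter, so neither the configuration change nor the acetyl change separates any two members on its own. What compound 4 adds is a second reading of the acetyl change, which shows that this change does not carry over unchanged from one configuration as drawn to the other: the same change on two cores in this assay, a 1.6-fold higher number (0.21 log units; within the scatter) from compound 2 to compound 3 and a 1.7-fold lower number (0.22 log units; within the scatter) from compound 4 to compound 1, 2.7-fold (0.43 log units) apart, beyond the scatter of two such steps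

On these data alone, the four compounds carry only hydrogen or acetyl on this oxygen, so it remains open how a longer chain such as a butanoyl ester, or an amine in place of that oxygen, would read on either configuration. As far as these compounds go, it also remains open whether the two configurations at the saturated ring carbons would differ in the same way with any group other than these two.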